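Methoxy for methyl on the aryl triazole of compound 1

The source may report more compounds than this note shows. Statements on the series, on what has been measured and on what is new or still open speak of the compounds shown alone.

The starting point is compound 1, `Cc1ccc(-c2cn(-c3cc4ccc(O)c(C)c4oc3=O)nn2)cc1`, which in a functional assay on MCF7 cells (Homo sapiens) for antiproliferative activity (on this read-out lower numbers stand for stronger inhibition and higher numbers for weaker inhibition), gives 23200 nM. Among the measured compounds shown here, that is the only numerical value in this set; the other two compounds come back as limits. Compound 2, `CC(=O)Oc1ccc2cc(-n3cc(-c4ccc(C)cc4)nn3)c(=O)oc2c1C`, carries an acetyl in place of the hydrogen on the phenolic oxygen, and in this assay compound 2 gives > 100000 nM, a limit of the assay. The step of an at least 4.3-fold higher number from compound 1 to compound 2 (0.63 log units; beyond the scatter) is therefore at least modest and beyond the scatter. Compound 3, `CO[C@@H]1[C@@H](O)[C@@H](O)[C@H](Oc2ccc3c(c2C)OC(=O)C(n2cc(-c4ccc(F)cc4F)nn2)C3)OC1(C)C`, is built on a different saturated core and sugar, and in this assay compound 3 gives > 100000 nM, again a limit of the assay. The series is thus dominated by the limit of > 100000 nM in this assay, at which 2 of the 3 values shown sit.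

Compound 4, `COc1ccc(-c2cn(-c3cc4ccc(O)c(C)c4oc3=O)nn2)cc1`, differs from compound 1 by methoxy in place of methyl on an aromatic carbon, that is, 4-methylphenyl becomes 4-methoxyphenyl. For the measured compounds named here, no measured step touches this aryl ring: the single step, from compound 1 to compound 2, concerns the phenolic oxygen on the shared core, so it says nothing directly about the methyl. The swap adds one hydrogen-bond acceptor and is small, so for compound 4 the expected step of a 1.0-fold lower number from compound 1 to compound 4 (0.00 log units; within the scatter) is none beyond the scatter. Compound 4 is accordingly estimated at 23000 nM, within 8000 nM to 70000 nM.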

Compound 4, half-maximal inhibitory concentration: > 100000 nM
Compound 4: no number, only a limit (the forecaster's own chance of this, stated with the estimate: 20%); middle value at least 4.3-fold (0.63 log units) away from the limit.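

The 4-methylphenyl group, which the earlier step left untouched, proves not to be a neutral place in this assay: methoxy in place of methyl on this aromatic carbon gives an at least 4.3-fold higher number from compound 1 to compound 4 (0.63 log units; beyond the scatter). Among the compounds shown here, until now, only the phenolic oxygen on the shared core had been seen to matter, with an at least 4.3-fold higher number from compound 1 to compound 2 (0.63 log units; beyond the scatter), so the single numerical value now depends on at least two separate places in the molecule. The step has a lower bound only, and compound 4 leaves the series with one numerical value, that of compound 1, as the rest of the series now stands at a limit: the limit of > 100000 nM in this assay, at which 3 of the 4 values shown sit.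

On these data alone, it remains open whether a chlorine, an ethyl or an amine at this same aromatic carbon would give a numerical value in this assay, and so whether methyl is specifically needed there or methoxy alone is not tolerated. The two changes also cannot be ranked against each other, as compound 2 and compound 4 both stop at a limit.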